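Adding a methoxy group to compound 3

The source may report more compounds than this note shows. Statements on the series, on what has been measured and on what is new or still open speak of the compounds shown alone.

In a functional assay on RXF 393 cells (Homo sapiens) for inhibition, read by sulforhodamine B assay, with a stated time of 48 h, tested at 10 uM (a lower number here means less inhibition of growth, a higher number more inhibition of growth at the concentration tested), compound 1 (`COc1ccc(-c2nc3sc(-c4ccccc4)cn3n2)cc1`) gives 24% and compound 2 (`COc1cc(-c2nc3sc(-c4ccccc4)cn3n2)cc(OC)c1OC`) gives 17% while compound 3 (`Clc1ccc(-c2cn3nc(-c4ccccc4)nc3s2)cc1`) reaches 39% as the highest of the three. The lead of compound 3 over each of the other two lies beyond the usual scatter.

Compound 4 (`COc1ccc(-c2nc3sc(-c4ccc(Cl)cc4)cn3n2)cc1`) follows from compound 3 by a single change (methoxy in place of hydrogen on an aromatic carbon): methoxy in place of hydrogen on an aromatic carbon of a six-membered aromatic ring of carbon only, para to a large group. Within the data shown here, no two measured compounds differ in one place only, so the data hold no direct measure of what this change does. Compound 4 combines the methoxy group of compound 1 with the chlorine of compound 3. Its number is therefore expected to lie between compound 1 at 24% and compound 3 at 39% but nearer the upper value. The expected change is a small fall that stays within the usual scatter (a number 6 percentage points lower from compound 3 to compound 4 (within the scatter)). In this assay the estimated value for compound 4 is 33% (range 18% to 48%).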

Compound 4, percent growth inhibition at one concentration: 41%
Estimate against measurement, compound 4: 8 percentage points below; the measured number falls inside the stated range.
By their numbers in this assay, from the lowest: compounds 2 and 1 (each within the scatter of the next); then compounds 3 and 4 (each within the scatter of the next).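

Among these compounds, for the first time, the methoxy group can be read on its own: in this assay, placing it on an aromatic carbon of the six-membered ring, para to a large group, gives a number 2 percentage points higher from compound 3 to compound 4 (within the scatter), so compound 3 and compound 4 cannot be told apart at this concentration. The chloro group now has its own single-place reading too, as chloro in place of hydrogen on an aromatic carbon gives a number 17 percentage points higher from compound 1 to compound 4 (beyond the scatter), which is a step beyond the scatter and sets it apart from the methoxy step. No measurement shown here accounts for either step.

The compounds shown leave open whether this place would read the same with an ethoxy group, an amine or a carboxylic acid in place of the methoxy group, since one pair alone cannot show how much this position tolerates. They also leave open whether the chloro step would hold on a compound without the methoxy group, as it rests on a single pair.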